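Quinolone amides on KYSE-70: toward compound 3

A few compounds are considered here, and "the series" means these few. Any claim that something is new, unique, unknown or untested is made for them only; others in the source may bear on it.

Among the compounds with values here, in a functional assay on KYSE-70 cells for antiproliferative activity against KYSE-70 cell line (Homo sapiens), read by MTT assay, with a stated time of 72 h (on this read-out higher numbers stand for weaker inhibition and lower numbers for stronger inhibition), compound 2 `O=C(Nc1cccc(F)c1)c1cc(=O)[nH]c2cc(-c3cccc(F)c3)ccc12` gives 12000 nM, the only actual number so far. Compound 1 `O=C(Nc1cccc(F)c1)c1cc(=O)[nH]c2cc(-c3ccccc3)ccc12` reaches only a limit of the assay, > 20000 nM (the limit of > 20000 nM in this assay, at which 1 of the 2 values shown sits). Within the data shown here, the single measured step, an at least 1.6-fold lower number from compound 1 to compound 2 (0.22 log units; that floor lies within the scatter), is fluoro in place of hydrogen on an aromatic carbon. Compound 3 `Cc1cc(-c2ccc3c(C(=O)Nc4cccc(F)c4)cc(=O)[nH]c3c2)c(C)cc1F` differs from compound 2 by 4-fluoro-2,5-dimethylphenyl in place of 3-fluorophenyl on an aromatic carbon. Among the measured compounds shown here, no measured step covers the added methyls, so little change beyond the scatter is expected in this assay, perhaps a small gain. Compound 3 is expected at 8000 nM, between 3000 nM and 20000 nM. The expected change is a 1.5-fold lower number from compound 2 to compound 3 (0.18 log units; within the scatter).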

Compound 3, half-maximal inhibitory concentration: > 20000 nM
Compound 3: only a limit was reported; the forecaster's own chance of this, stated with the estimate: 25%; at least 2.5-fold (0.39 log units) between middle value and limit.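

In this assay, 4-fluoro-2,5-dimethylphenyl in place of 3-fluorophenyl gives an at least 1.6-fold higher number from compound 2 to compound 3 (0.22 log units; that floor lies within the scatter), so the added methyls on this aromatic carbon bring no gain, though the step cannot be told from no change. Compound 3 stays at a limit of the assay, > 20000 nM. The step between compound 1 and compound 3 cannot be read, and most of the series now sits at that limit: the limit of > 20000 nM in this assay, at which 2 of the 3 values shown sit.

Still open, as far as these compounds go, is how far compound 3 lies past that limit. Also open, from the compounds shown here alone, is whether an amine, a carboxylic acid or a longer chain on this aromatic carbon would give a lower number than compound 2.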